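Furanyl for chlorophenyl on the methyl-bearing indole analogue

The source may report more compounds than this note shows. Statements on the series, on what has been measured and on what is new or still open speak of the compounds shown alone.

Measured so far in the series:
compound 1 `COc1ccc(Cl)c(-c2nnc3sc(Cc4c[nH]c5ccc(OC)cc45)nn23)c1` — in a functional assay on the whole organism (strain Wistar Albino) for inhibition, with Rattus norvegicus as the target, read by paw edema, with a stated time of 4 h, at a dose of 20 mg/kg (on this read-out higher numbers stand for more inhibition at the one dose given (going by the name of the read-out) and lower numbers for less inhibition), compound 1 gives 33.9%
compound 2 `COc1ccc2[nH]cc(Cc3nn4c(-c5ccoc5C)nnc4s3)c2c1` — compound 2 gives 30.8%
compound 3 `COc1ccc(Cl)c(-c2nnc3sc(Cc4c(C)[nH]c5ccc(OC)cc45)nn23)c1` — compound 3 gives 32.7%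

Compound 3 stands second highest of the three numbers in this assay. Its nearest neighbour is compound 1, the gap being within the scatter, and the gap to compound 2 is within the scatter as well, so no order among the three compounds can be read from these numbers.

Compound 4 `COc1ccc2[nH]c(C)c(Cc3nn4c(-c5ccoc5C)nnc4s3)c2c1` has not been measured. It differs from compound 3 in one place: 2-methylfuran-3-yl in place of 2-chloro-5-methoxyphenyl on an aromatic carbon

Within the data shown here, one measured step bears directly on this change, the same exchange made on the core that carries hydrogen instead of methyl: a number 3.1 percentage points lower from compound 1 to compound 2 (within the scatter). The methyl itself, judged by a number 1.2 percentage points lower from compound 1 to compound 3 (within the scatter), moves the read-out little. Both steps sit within the scatter, so the exchange on compound 3 is expected to give no step beyond the scatter in this assay, the estimated step being a number 2.7 percentage points lower from compound 3 to compound 4 (within the scatter). Compound 4 is therefore expected to show about 30%, with a range from 22% to 38%.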

Compound 4, a percentage reported as inhibition, in the whole organism at one dose (the size of the read-out at that dose, not a potency): 31.2%
Beside the measured number, compound 4's estimate is 1.2 percentage points below it, and the stated range covers the measured number.
By their numbers in this assay, from the lowest: compounds 2, 4, 3 and 1 (each within the scatter of the next).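

In this assay, the exchange to 2-methylfuran-3-yl from 2-chloro-5-methoxyphenyl, on an aromatic carbon of a five-membered aromatic ring with 3 nitrogen, now has a reading on a second core, a number 1.5 percentage points lower from compound 3 to compound 4 (within the scatter), and it agrees with the first: the same change on two cores in this assay, a number 3.1 percentage points lower (within the scatter) from compound 1 to compound 2 and a number 1.5 percentage points lower (within the scatter) from compound 3 to compound 4, 1.6 percentage points apart, within the scatter of two such steps. The methyl in place of hydrogen also gains a second reading, a number 0.4 percentage points higher from compound 2 to compound 4 (within the scatter), and the two readings again agree: the same change on two cores in this assay, a number 1.2 percentage points lower (within the scatter) from compound 1 to compound 3 and a number 0.4 percentage points higher (within the scatter) from compound 2 to compound 4, 1.6 percentage points apart, within the scatter of two such steps. With both changes read on two cores, no step among these compounds goes beyond the scatter, so this read-out does not separate a six-membered aromatic ring of carbon only from a five-membered aromatic ring with 1 hetero atom at this position, on either core.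

As far as these compounds go, it remains open whether any group on this carbon, such as an aminomethyl group or a carboxylic acid, would give a step beyond the scatter in this assay. The compounds shown also leave open whether the same lack of separation would hold at another dose or another time.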